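A few compounds are considered here, and "the series" means these few. Any claim that something is new, unique, unknown or untested is made for them only; others in the source may bear on it.

Working notes on the series.

Compound 2 `C[C@@H](O[C@H]1CN2C(=O)C=C(c3cnn(Cc4ccccc4)c3)CC2[C@@H]1c1ccc(F)cc1)c1cc(C(F)(F)F)cc(C(F)(F)F)c1` gives the higher of the two numbers in an assay on CHO cells for displacement of a labelled ligand from Substance-P receptor (Homo sapiens), in the presence of a further agent that is not named here (on this read-out higher numbers stand for weaker inhibition and lower numbers for stronger inhibition), with compound 2 at 66 nM, while compound 1 `C[C@@H](O[C@H]1CN2C(=O)C=C(c3cnn(C)c3)CC2[C@@H]1c1ccc(F)cc1)c1cc(C(F)(F)F)cc(C(F)(F)F)c1` gives 5.4 nM. For the measured compounds named here, the one measured step, a 12-fold higher number from compound 1 to compound 2 (1.09 log units; beyond the scatter), is the only guide. Compound 3 `C[C@@H](O[C@H]1CN2C(=O)C=C(C3=CCC(O)CC3)CC2[C@@H]1c1ccc(F)cc1)c1cc(C(F)(F)F)cc(C(F)(F)F)c1` is not yet measured; it differs from compound 2 by 4-hydroxycyclohex-1-en-1-yl in place of 1-benzyl-1H-pyrazol-4-yl on a double-bonded ring carbon.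

The step of a 12-fold higher number from compound 1 to compound 2 (1.09 log units; beyond the scatter) came with the introduction of the phenyl. Going by the values given here, the change from compound 2 to compound 3 removes that phenyl, but it also replaces the pyrazole ring that compound 1 and compound 2 share with a hydroxycyclohexenyl ring, for which no step is recorded here. The measured step therefore bears only in part: the loss of the phenyl suggests a move back toward the number of compound 1, but the ring exchange adds uncertainty in either direction, so a smaller move than the measured step is expected. The expected step is a 4.4-fold lower number from compound 2 to compound 3 (0.64 log units; beyond the scatter). Compound 3 is therefore estimated at 15 nM, within a range from 4 nM to 60 nM.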

Compound 3, half-maximal inhibitory concentration: 13 nM
For compound 3 the middle estimate is 1.2-fold (0.06 log units) above the measured one, and the stated range covers the measured number.
By their numbers in this assay, from the lowest: compound 1; then compound 3; then compound 2.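

The aromatic pyrazole is not needed at this double-bonded ring carbon for a number in the range of this series: in this assay there is a 5.1-fold lower number from compound 2 to compound 3 (0.71 log units; beyond the scatter), and the entering 4-hydroxycyclohex-1-en-1-yl is a single non-aromatic carbocycle carrying a hydrogen-bond donor. Against the smaller pyrazole substituent the same ring gives a 2.4-fold higher number from compound 1 to compound 3 (0.38 log units; beyond the scatter), so compound 3 falls between compound 1 and compound 2, and the 1-methyl-1H-pyrazol-4-yl group keeps the lowest number of the three, while a non-aromatic ring with a hydroxyl at this position gives up much less than the benzyl group does in a 12-fold higher number from compound 1 to compound 2 (1.09 log units; beyond the scatter). Nothing available explains these differences, and the steps stand as observations only.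

Going by these compounds, what the hydroxyl itself contributes stays open, since the ring and the hydroxyl enter together in one change; a comparison of compound 3 with the unsubstituted cyclohexenyl ring, or with an amine or a carboxylic acid in place of the hydroxyl, would separate them. On these data alone, the role of the ring double bond is equally open, and the saturated 4-hydroxycyclohexyl ring would bear on it.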